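The compounds below may be only part of what the source reports. "The series", "measured", "known", "first", "only" and "open" are said of these compounds alone.

Working notes on the amide series. Compound 1 `COc1cc2nc(C)cc(OCC(=O)Nc3cc(C)cc(C)c3)c2cc1OC` in a toxicity assay on HepG2 cells (Homo sapiens) for inhibition, read by CellTiter-Glo, with a stated time of 48 h (on this read-out higher numbers stand for weaker inhibition and lower numbers for stronger inhibition), gives 10000 nM. Compound 2 `COc1ccc2nc(C)cc(OCC(=O)Nc3ccccc3)c2c1` in this assay gives 39800 nM. Compound 3 `COc1ccc2nc(C)cc(OCC(=O)Nc3cc(C)ccc3OC)c2c1` in this assay reaches only a limit of the assay, > 100000 nM, so where compound 3 stands is known as a range and not as a number. The step of an at least 2.5-fold higher number from compound 2 to compound 3 (0.40 log units; beyond the scatter) is accordingly a lower bound on the change, ending at the limit (the limit of > 100000 nM in this assay, at which 1 of the 3 values shown sits).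

Compound 4 `COc1ccc2nc(C)cc(OCC(=O)Nc3ccc(F)cc3)c2c1` carries 4-fluorophenyl in place of 2-methoxy-5-methylphenyl on an amide-type nitrogen. For the measured compounds named here, the one measured step that bears on this position is an at least 2.5-fold higher number from compound 2 to compound 3 (0.40 log units; beyond the scatter), in which the plain phenyl on the amide-type nitrogen was exchanged for the 2-methoxy-5-methylphenyl and the number rose at least modestly, to the limit. Compound 4 moves back toward the phenyl of compound 2: the 4-fluorophenyl keeps the six-membered aromatic ring of carbon only, carries no hydrogen-bond acceptor, and adds one fluorine in place of the methoxy and methyl. A downward step is expected, an at least 2.5-fold lower number from compound 3 to compound 4 (0.39 log units; beyond the scatter), roughly reversing the earlier rise, though a result at the limit again cannot be excluded on so few points. Compound 4 in this assay is expected near 40000 nM, within 15000 nM to 100000 nM.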

Compound 4, half-maximal inhibitory concentration: 63100 nM
For compound 4 the middle estimate is 1.6-fold (0.20 log units) below the measured one, and the stated range covers the measured number.
By their numbers in this assay, from the lowest: compound 1; then compounds 2 and 4 (each within the scatter of the next). At a limit, above all of these: compound 3.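

Within the aryl group on the amide-type nitrogen, a 1.6-fold higher number from compound 2 to compound 4 (0.20 log units; within the scatter) in this assay shows that fluoro in place of hydrogen on an aromatic carbon gives no change that can be separated from the plain phenyl, whereas the only step beyond the scatter at this position so far is an at least 2.5-fold higher number from compound 2 to compound 3 (0.40 log units; beyond the scatter). The return from the 2-methoxy-5-methylphenyl, an at least 1.5-fold lower number from compound 3 to compound 4 (0.19 log units; that floor lies within the scatter), is only a floor, so it does not yet establish a real difference between that group and the 4-fluorophenyl. Compound 3 stands at a limit of the assay, > 100000 nM, and the full size of that step therefore remains unknown: the limit of > 100000 nM in this assay, at which 1 of the 4 values shown sits.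

The compounds shown leave open whether the methoxy or the methyl of the 2-methoxy-5-methylphenyl accounts for the step from the plain phenyl, since the two groups enter together and neither is seen alone on the ring. Also open, on these data alone, is whether an amine or a carboxylic acid on the phenyl, in place of the fluoro, would give a step from compound 2 beyond the scatter.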